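The source may hold more compounds than are shown below. What is called first, only, known or untested is meant among the compounds shown, and "the series" means these compounds.

Measured compounds:
compound 1 `c1ccc(-c2nc3ncccn3c2CN2CCCC2)cc1`, 50 nM;
compound 2 `CC(C)(C)c1nc2ncccn2c1CN1CCCCC1`, 330 nM;
compound 3 `Cc1ccn2c(CN3CCCCC3)c(C(C)(C)C)nc2n1`, 7390 nM.

In a functional assay on A549 cells (Homo sapiens) for inhibition, read by sulforhodamine B assay, with a stated time of 48 h (a lower number here means a stronger inhibitor of growth, a higher number a weaker inhibitor of growth), compound 1 gives the lowest number of the three, compound 2 a higher one and compound 3 the highest. Compound 2 and compound 3 differ by one change, (methyl in place of hydrogen on an aromatic carbon), and that change made a large step: a 22-fold higher number from compound 2 to compound 3 (1.35 log units; beyond the scatter). The difference between the core of compound 1 and the core of compound 2 is not broken down here. Compound 4 `Cc1ccn2c(CN3CCCC3)c(-c3ccccc3)nc2n1`, not yet measured, carries the same change relative to compound 1: methyl in place of hydrogen on an aromatic carbon. Since the change is the same at the same place, a step of similar size is expected, so compound 4 is expected to show a 22-fold higher number from compound 1 to compound 4 (1.34 log units; beyond the scatter) in this assay, resting on the step seen from compound 2 to compound 3. The estimate for compound 4 is 1100 nM, spanning 300 nM to 4000 nM.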

Compound 4, concentration for 50% growth inhibition: 4150 nM
For compound 4 the middle estimate is 3.8-fold (0.58 log units) below the measured one; measured number above the stated range.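

In this assay, methyl in place of hydrogen on an aromatic carbon gave an 83-fold higher number from compound 1 to compound 4 (1.92 log units; beyond the scatter). The direction of the step therefore carried over between the two cores, but its size did not: the same change on two cores in this assay, a 22-fold higher number (1.35 log units; beyond the scatter) from compound 2 to compound 3 and an 83-fold higher number (1.92 log units; beyond the scatter) from compound 1 to compound 4, 3.7-fold (0.57 log units) apart, beyond the scatter of two such steps. Two pairs do not show which part of the cores sets the sizes apart, as compound 1 and compound 2 differ in more than one place, and they say nothing about other cores in the series.

Going by these compounds, it remains open whether an ethyl group, a methoxy group or an amine at this place would raise the number as methyl does. On these data alone, it is also open whether methyl on another carbon of that six-membered aromatic ring would do the same.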